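The source may report more compounds than this note shows. Statements on the series, on what has been measured and on what is new or still open speak of the compounds shown alone.

In an ADME assay for permeability, using PAMPA, with a stated time of 10 h, tested at 100 ug/mL (on this read-out lower numbers stand for lower permeability and higher numbers for higher permeability), compound 1 (`Oc1cccc2ccc(-c3cc4cc(F)ccc4[nH]3)nc12`) gives 10.6 10^-6 cm/s and compound 2 (`Oc1ccc2[nH]c(-c3ccc4cccc(O)c4n3)cc2c1`) gives 14.8 10^-6 cm/s while compound 3 (`COc1cc2cc(-c3ccc4cccc(O)c4n3)[nH]c2cc1OC`) gives 5.2 10^-6 cm/s as the lowest of the three numbers. The gaps from compound 3 to compound 1 and to compound 2 both lie beyond the scatter.

Compound 4 (`COc1cc2[nH]c(-c3ccc4cccc(O)c4n3)cc2cc1O`) differs from compound 3 as follows: hydrogen in place of methyl on an oxygen on an aromatic ring (hydrogen in place of methyl on an oxygen on an aromatic ring, or methoxy to hydroxy). Going by the values given here, no measured pair shows this change directly. The closest evidence is a 1.4-fold higher number from compound 1 to compound 2 (0.14 log units; within the scatter) where hydroxy takes the place of fluoro on an aromatic carbon, a different group leaving, and that step stays within the scatter. On this thin basis, no step beyond the scatter is expected in this assay for the new change, with only a slight lean towards a higher number. The expected change is a 1.2-fold higher number from compound 3 to compound 4 (0.06 log units; within the scatter) and it is only an estimate. For compound 4 the estimated value is 6 10^-6 cm/s with an expected range of 3 10^-6 cm/s to 12 10^-6 cm/s as the working window.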

Compound 4, apparent permeability: 12.1 10^-6 cm/s
The estimate for compound 4 lay 2.0-fold (0.30 log units) below the measured number, and the stated range ends below it.
By their numbers in this assay, from the lowest: compound 3; then compounds 1, 4 and 2 (each within the scatter of the next).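

In this assay, the methoxy to hydroxy change on an oxygen on an aromatic ring now has a direct reading (a 2.3-fold higher number from compound 3 to compound 4 (0.37 log units; beyond the scatter)), and this step lies beyond the scatter, unlike the earlier hydroxy in place of fluoro step. Methoxy in place of hydrogen on an aromatic carbon, read with a hydroxy already present, gives a step that stays within the scatter (a 1.2-fold lower number from compound 2 to compound 4 (0.09 log units; within the scatter)), so that compound pair shows no separation in this assay. No measurement in hand accounts for either step.

As far as these compounds go, whether the same change on the remaining methoxy of compound 4 would give a similar step stays open, as does the reading for an ethoxy or longer chain on this oxygen, or for an amine in place of the hydroxy. A single pair also cannot show whether methoxy to hydroxy reads alike on another core.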